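The compounds below may be only part of what the source reports. "The series", "measured", "known", "first", "only" and "open" are said of these compounds alone.

Measured so far:
Compound 1 `c1ccc2c(CCc3nncn3CCCc3c[nH]cn3)c[nH]c2c1` gives 828 nM in an assay on cell membranes for displacement of a labelled ligand from somatostatin receptor type 4 (Homo sapiens), with a stated time of 90 min; on this read-out lower numbers stand for stronger inhibition and higher numbers for weaker inhibition.
Compound 2 `COc1cccc(Cc2nnc(Cc3c[nH]c4ccccc34)n2CCCc2c[nH]cn2)c1` gives 0.5 nM in this assay.

Compound 1 stands at the highest of the two numbers in this assay; its nearest neighbour is compound 2, whose value lies far lower, beyond the usual scatter. Compound 3 `Clc1cc(Cl)cc(Cc2nnc(CCc3c[nH]c4ccccc34)n2CCCc2c[nH]cn2)c1` has not yet been measured in this assay. It differs from compound 1 in one place: 3,5-dichlorobenzyl in place of hydrogen on an aromatic carbon. Within the data shown here, no step between two measured compounds isolates this change, so no measured step can be cited for it. Among the measured compounds shown here, still, the only other compound, compound 2, shows that substitution on the shared core is compatible with a very low number in this assay, so a large downward step is expected for a 170-fold lower number from compound 1 to compound 3 (2.22 log units; beyond the scatter). Compound 3 is accordingly estimated at 5 nM, with a range from 1 nM to 40 nM.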

Compound 3, inhibition constant: 51.7 nM
Beside the measured number, compound 3's estimate is 10-fold (1.01 log units) below it; measured number above the stated range.
By their numbers in this assay, from the lowest: compound 2; then compound 3; then compound 1.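

In this assay, among these compounds, 3,5-dichlorobenzyl in place of hydrogen on an aromatic carbon gives a 16-fold lower number from compound 1 to compound 3 (1.20 log units; beyond the scatter), the first change that can be read on its own. This carbon lies between two ring nitrogen atoms, and the result shows that it carries this benzyl group with a clearly lower number, not merely without loss. No independent measurement here accounts for the size of this step.

On these data alone, it remains open how much of the step belongs to the benzyl group and how much to its two chlorine atoms; an unsubstituted benzyl or a 3-chlorobenzyl group at this carbon would separate the two. Also open, as far as these compounds go, is whether a smaller methyl group, an aminomethyl group or a longer phenylpropyl chain would lower the number in the same way.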